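Working notes: from compound 3 to compound 4

This account rests on a few compounds, and the source may have more. Where it says the series, first, only, none or still open, it means among the compounds named here.

Values in a functional assay on MCF7 cells (Homo sapiens) for cytotoxicity, read by ELISA, with a stated time of 4 days (on this read-out lower numbers stand for stronger inhibition and higher numbers for weaker inhibition), so far:
- compound 1 `Cc1ccsc1-c1cc(-c2ccoc2)cc(-c2ccc(Cl)cc2)n1` gives 20300 nM 
- compound 2 `Cc1ccccc1-c1cc(-c2ccoc2)cc(-c2ccc(Cl)s2)n1` gives 1430 nM 
- compound 3 `Cc1cccc(-c2cc(-c3ccoc3)cc(-c3ccc(Cl)s3)n2)c1` gives 3990 nM 

Compound 3 holds the second highest of the three numbers, with compound 2 nearest and lower and compound 1 furthest and higher, both gaps beyond the scatter. The next structure is compound 4 `Clc1ccc(-c2cc(-c3ccoc3)cc(-c3ccc(Cl)s3)n2)cc1` with 4-chlorophenyl in place of 3-methylphenyl on an aromatic carbon next to the ring nitrogen, and the counted difference is 4-chlorophenyl in place of 3-methylphenyl on an aromatic carbon in full.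

For the measured compounds named here, the one measured step at this place is a 2.8-fold higher number from compound 2 to compound 3 (0.45 log units; beyond the scatter) and it is modest, though it only moves a methyl and brings in no chlorine. Compound 1 also carries 4-chlorophenyl and gives 20300 nM with a different group elsewhere, so it is no clean comparison, yet it tilts the expectation slightly toward a higher number. In this assay a small step, not beyond the scatter, is therefore expected. The estimated change is a 1.3-fold higher number from compound 3 to compound 4 (0.10 log units; within the scatter) in this read-out. For compound 4 the estimate is 5000 nM with an expected range from 1600 nM to 15000 nM in this read-out.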

Compound 4, half-maximal inhibitory concentration: 2600 nM
Beside the measured number, compound 4's estimate is 1.9-fold (0.28 log units) above it; low and high end bracket the measured number.
By their numbers in this assay, from the lowest: compounds 2, 4 and 3 (each within the scatter of the next, the first and the last beyond it); then compound 1.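

In this assay, the step of a 1.5-fold lower number from compound 3 to compound 4 (0.19 log units; within the scatter) and the step of a 1.8-fold higher number from compound 2 to compound 4 (0.26 log units; within the scatter) place 4-chlorophenyl within the scatter of both methylphenyl compounds at the aromatic carbon next to the ring nitrogen. For the compounds shown here, this position therefore accepts a chlorine on the phenyl ring in place of a methyl without a reading beyond the scatter, whereas moving the methyl alone gave a 2.8-fold higher number from compound 2 to compound 3 (0.45 log units; beyond the scatter) and remains the only step at this position that lies beyond it. The new compound also opens a second comparison with 4-chlorophenyl held fixed, and the change at the other aromatic carbon gives a 7.8-fold lower number from compound 1 to compound 4 (0.89 log units; beyond the scatter) and so lies beyond the scatter, which shows that the series responds to 5-chlorothiophen-2-yl in place of 3-methylthiophen-2-yl.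

From the compounds shown here alone, how an amine or a carboxylic acid on the phenyl ring would read at this position remains open, as does the contribution of the furan-3-yl group, which all four compounds share. No supporting measurement is available to explain any of these steps, so the numbers describe the changes without accounting for them.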